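Sulfonamide piperidine series: amine variation on the trimethylphenyl core

The source may hold more compounds than are shown below. What is called first, only, known or untested is meant among the compounds shown, and "the series" means these compounds.

Compound 1 `Cc1cc(C)c(S(=O)(=O)N2CCC(N3CCN(C)CC3)CC2)c(C)c1` carries a 4-methylpiperazin-1-yl group; in a functional assay on DLD-1 cells (Homo sapiens) for antiproliferative activity, read by CellTiter-Glo, with a stated time of 72 h (on this read-out lower numbers stand for stronger inhibition and higher numbers for weaker inhibition), compound 1 gives 1100 nM, the higher of the two numbers recorded so far. Compound 2 `Cc1ccc(-c2cccc(S(=O)(=O)N3CCC(N4CCC(C)CC4)CC3)c2)cc1` differs in more than one place and in this assay compound 2 gives 11 nM; the two values lie apart beyond the scatter. Compound 3 `Cc1cc(C)c(S(=O)(=O)N2CCC(N3CCCCC3)CC2)c(C)c1` is compound 1 with piperidin-1-yl in place of 4-methylpiperazin-1-yl on a saturated ring carbon. Within the data shown here, no measured pair with this single change exists, so the direction rests on an expectation only. A modest move toward lower numbers is expected, a step of a 2.8-fold lower number from compound 1 to compound 3 (0.44 log units; beyond the scatter). Compound 3 is estimated at 400 nM in this assay, within the range 100 nM to 1500 nM.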

Compound 3, half-maximal inhibitory concentration: 2200 nM
Compound 3: the middle estimate sits 5.5-fold (0.74 log units) below what was measured; the measured number lies above the stated range.
By their numbers in this assay, from the lowest: compound 2; then compounds 1 and 3 (each within the scatter of the next).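

In this assay, piperidin-1-yl in place of 4-methylpiperazin-1-yl on the saturated ring carbon gives a 2.0-fold higher number from compound 1 to compound 3 (0.30 log units; within the scatter) on the shared core. The assay therefore does not separate these two ring amines at this position, and the second ring nitrogen with its methyl group has no readable effect on the number here. Nothing available accounts for this result. Still open, as far as these compounds go, is whether a morpholine or an open-chain dimethylamino group at this carbon would stay within the same range. Also open, from the compounds shown here alone, is whether a ring amine carrying a hydroxyl group would move the number on this core.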